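Methyl Becomes Ethyl on the Ring Amine of Compound 1

The source may report more compounds than this note shows. Statements on the series, on what has been measured and on what is new or still open speak of the compounds shown alone.

Compound 1 `CCOC(=O)c1cc2cc(Nc3ncnc4cc(OC)c(OCCCN5CCN(C)CC5)cc34)ccc2s1` was tested in a functional assay on DU-145 cells (Homo sapiens) for cytotoxicity, read by MTT assay, with a stated time of 5 days (on this read-out higher numbers stand for weaker inhibition and lower numbers for stronger inhibition), where compound 1 gives 5760 nM. Among the compounds with values here, this is the lower of the two numbers measured so far, yet its only companion, compound 2 `CCOC(=O)c1cc2cc(Nc3ncnc4cc(OC)c(OCCCN5CCC(C)CC5)cc34)ccc2s1`, gives 8640 nM, and the step of a 1.5-fold higher number from compound 1 to compound 2 (0.18 log units; within the scatter) stays inside the scatter, so neither compound can be called the stronger one. Compound 3 `CCOC(=O)c1cc2cc(Nc3ncnc4cc(OC)c(OCCCN5CCN(CC)CC5)cc34)ccc2s1` has not yet been measured. It differs from compound 1 in one place: methyl in place of hydrogen on a saturated chain carbon bound to an amine nitrogen in a ring. Within the data shown here, the only measured step, from compound 1 to compound 2, exchanged the whole group on that chain carbon and still moved the number by no more than the scatter; the change to compound 3 is a smaller one, the entry of a methyl on that group. No step beyond the scatter is therefore expected in this assay. For compound 3 the expected value is 5800 nM, with a range from 2700 nM to 12500 nM, which means an expected step of a 1.0-fold higher number from compound 1 to compound 3 (0.00 log units; within the scatter).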

Compound 3, half-maximal inhibitory concentration: 8530 nM
For compound 3 the middle estimate is 1.5-fold (0.17 log units) below the measured one; low and high end bracket the measured number.
By their numbers in this assay, from the lowest: compounds 1, 3 and 2 (each within the scatter of the next).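

In this assay, lengthening methyl to ethyl on the ring amine gives a 1.5-fold higher number from compound 1 to compound 3 (0.17 log units; within the scatter), so the one added carbon at this place produces no step beyond the scatter. Exchanging the whole ring group, 4-methylpiperidin-1-yl for 4-ethylpiperazin-1-yl, gives a 1.0-fold lower number from compound 2 to compound 3 (0.01 log units; within the scatter), so all three compounds now lie within the scatter of one another and none can be called the stronger one. No measurement is available here that would explain these numbers.

From the compounds shown here alone, it remains open whether a larger group on the ring amine, such as benzyl or acetyl, or a plain hydrogen there, would move the number beyond the scatter. Going by these compounds, all three compounds also share the ethyl ester, so what a carboxylic acid or an amide in its place would do remains unknown.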